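The compounds below may be only part of what the source reports. "The series", "measured", "known", "first", "only" and "open" are said of these compounds alone.

In an ADME assay on the whole organism (plasma, Rattus norvegicus) for protein binding, using cassette dosing, at a dose of 1 mg/kg (a higher number here means a larger unbound share of the compound, a lower number a smaller unbound share), compound 1 `C[C@@H](Cn1c(=O)[nH]/c(=N\c2ccc(Oc3ccc(F)cn3)cc2)n(Cc2ccc(Cl)cc2)c1=O)C(=O)O` gives 0.011, while compound 2 `CC(C)Oc1ccc(/N=c2\[nH]c(=O)n(CC(C)(C)C(=O)O)c(=O)n2Cc2ccc(Cl)cc2)cc1Cl` gives 0.003. Compound 1 therefore has the higher of the two numbers, and its gap to compound 2 lies beyond the usual scatter of repeated measurements. Both numbers are small, so only a little of either compound is unbound. Compound 3 `C[C@@H](Cn1c(=O)[nH]/c(=N\c2ccc(OC3CCC3)cc2)n(Cc2ccc(Cl)cc2)c1=O)C(=O)O`, not yet measured, keeps the rest of compound 1 and changes one group: cyclobutyl in place of 5-fluoropyridin-2-yl on an oxygen on an aromatic ring. Cyclobutyl stands in place of 5-fluoropyridin-2-yl on an oxygen on an aromatic ring. Going by the values given here, no measured pair here differs in one place, so the data do not yet size this change directly. A small downward move within the scatter is expected, and the estimated step is a 1.6-fold lower number from compound 1 to compound 3 (0.20 log units; within the scatter). For compound 3 the estimated unbound fraction is 0.007, with a range from 0.003 to 0.016.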

Compound 3, unbound fraction: 0.015
Beside the measured number, compound 3's estimate is 2.1-fold (0.33 log units) below it, and the stated range covers the measured number.
By their numbers in this assay, from the lowest: compound 2; then compounds 1 and 3 (each within the scatter of the next).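

In this assay, the step from 5-fluoropyridin-2-yl to cyclobutyl on an oxygen on an aromatic ring is a 1.4-fold higher number from compound 1 to compound 3 (0.13 log units; within the scatter) and gives the first direct measure of a change at this position. The entering group has 4 heavy atoms and no hydrogen-bond acceptor, whereas the leaving group has 7 heavy atoms and 1 hydrogen-bond acceptor, yet this pair cannot be told apart in the unbound fraction, and only a small share of either compound is unbound. Nothing at hand offers an explanation for this result.

On these data alone, whether a plain phenyl ring, an amine or a longer carbon chain on the same oxygen would also leave the number unmoved remains open. Compound 2 differs from these two compounds in more than one place, so its steps to them cannot be read.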